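Solubility estimate for a morpholine urea analogue

The source may report more compounds than this note shows. Statements on the series, on what has been measured and on what is new or still open speak of the compounds shown alone.

Measured so far:
Compound 1, `CC(C)(C)c1cc(NC(=O)[C@@H]2CCCCN2CC2CCOCC2)no1`, gives 72 ug/mL in a physicochemical assay for solubility, read by HPLC, at pH 6.8; on this read-out lower numbers stand for lower solubility and higher numbers for higher solubility.
Compound 2, `CC(C)(C)c1cc(NC(=O)[C@@H]2CCCCN2C(=O)CC2CCOCC2)no1`, gives 52 ug/mL in this assay.

For the measured compounds named here, compound 2 holds the lowest of the two numbers so far, with compound 1 as its nearest neighbour; the step of a 1.4-fold lower number from compound 1 to compound 2 (0.14 log units; within the scatter) lies within the scatter, so the two cannot be ordered. Going by the values given here, that step, an acyl group in place of an alkyl group on the ring nitrogen, is the only measured change that bears on what follows, and it was small.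

Compound 3, `CC(C)(C)c1cc(NC(=O)[C@@H]2CCCCN2C(=O)N2CCOCC2)no1`, has not yet been measured. Its difference from compound 2 is morpholin-4-yl in place of (oxan-4-yl)methyl on a carbonyl carbon. Among the compounds with values here, the only measured step that touches this position, from compound 1 to compound 2, stayed within the scatter, and nothing measured speaks to the exchange of the ring itself.

Compound 3 is therefore expected to give a number close to that of compound 2, with the step of a 1.3-fold higher number from compound 2 to compound 3 (0.13 log units; within the scatter) expected to stay within the scatter. The estimate for compound 3 is 70 ug/mL, with a range from 30 ug/mL to 160 ug/mL.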

Compound 3, solubility: 45 ug/mL
For compound 3 the middle estimate is 1.6-fold (0.19 log units) above the measured one; the range from low to high includes it.
By their numbers in this assay, from the lowest: compounds 3, 2 and 1 (each within the scatter of the next).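

In this assay, morpholin-4-yl in place of (oxan-4-yl)methyl on a carbonyl carbon gives a 1.2-fold lower number from compound 2 to compound 3 (0.06 log units; within the scatter), so this position now has an exchange of the ring itself on record, something the earlier pair did not cover, and that exchange stays within the scatter. Read at the amine nitrogen in a ring, (morpholin-4-yl)carbonyl in place of (oxan-4-yl)methyl gives a 1.6-fold lower number from compound 1 to compound 3 (0.20 log units; within the scatter), which is also within the scatter, so the three groups seen at this nitrogen cannot be ordered on this read-out, whether the ring carries one hetero atom or two and whether a carbonyl is present or not. No supporting evidence is available to explain this result, which therefore stands as a description only.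

The compounds shown leave open whether this position stays as flat with a group of a different kind on the carbonyl carbon, such as a piperazin-1-yl ring with a free amine, or a chain ending in a carboxylic acid. They also leave open whether a longer chain between the carbonyl carbon and the ring would stay within the scatter of these three compounds.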